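Replacing dimethylamino with hydrogen on compound 2

This account rests on a few compounds, and the source may have more. Where it says the series, first, only, none or still open, it means among the compounds named here.

In a functional assay on HeLa cells (Homo sapiens) for inhibition, read by MTT assay, with a stated time of 48 h (a lower number here means a stronger inhibitor, a higher number a weaker inhibitor), compound 2 (`CN(C)c1ccc(/C=C/C(=O)c2ccco2)cc1`) gives 20000 nM and compound 1 (`O=C(/C=C/c1ccc(Cl)cc1)c1ccco1`) gives 38000 nM there, two values within the scatter of each other. Compound 3 (`O=C(/C=C/c1ccccc1)c1ccco1`) has hydrogen in place of dimethylamino on an aromatic carbon relative to compound 2. Going by the values given here, the one measured step at that carbon (a 1.9-fold lower number from compound 1 to compound 2 (0.28 log units; within the scatter)) put dimethylamino in place of chloro and stayed within the scatter, so no step beyond the scatter is expected in this assay here. The estimated step (a 1.4-fold higher number from compound 2 to compound 3 (0.15 log units; within the scatter)) stays inside that scatter. The estimate for compound 3 is 28000 nM with an expected range from 12000 nM to 65000 nM for this measurement.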

Compound 3, half-maximal inhibitory concentration: > 100000 nM
Compound 3 gave a limit, no number; the forecaster's own chance of this, stated with the estimate: 10%; middle value at least 3.5-fold (0.55 log units) away from the limit.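

In this assay compound 3 gives a limit of the assay, not a number: the limit of > 100000 nM in this assay, at which 1 of the 3 values shown sits. Swapping chloro for dimethylamino on this aromatic carbon had stayed within the scatter, but removing either group does not: the new steps are an at least 5.0-fold higher number from compound 2 to compound 3 (0.69 log units; beyond the scatter) and an at least 2.6-fold higher number from compound 1 to compound 3 (0.42 log units; beyond the scatter). This position therefore responds to having hydrogen there, although compound 1 and compound 2 remain within the scatter of each other.

As far as these compounds go, the true size of both steps stays open, since compound 3 has only a limit. Also open, from the compounds shown here alone, is whether a methoxy group or a carboxylic acid on this carbon would behave like chloro and dimethylamino or like hydrogen.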